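Chloro for Isobutyl on a Chalcone Acid Scaffold

The source may hold more compounds than are shown below. What is called first, only, known or untested is meant among the compounds shown, and "the series" means these compounds.

Measured so far in an ADME assay on Vero cells (Chlorocebus sabaeus) for cytotoxicity, read by MTT assay, with a stated time of 72 h; on this read-out higher numbers stand for lower toxicity in this test and lower numbers for higher toxicity in this test:
compound 1 `COC(=O)c1cc(-c2cccc(NC(=O)c3ccc(/C=C/C(=O)c4cccc(Cl)c4)cc3)c2)on1`: > 2.5 ug/mL
compound 2 `CC(C)Cc1ccc(C(=O)/C=C/c2ccc(C(=O)O)cc2)cc1`: < 10 ug/mL
compound 3 `COC(=O)c1cc(-c2cccc(NC(=O)c3ccc(OCc4ccc(Cl)cc4)cc3)c2)on1`: > 80 ug/mL

Each of these three readings is a limit of this assay rather than a number. For compound 1 the reading > 2.5 ug/mL is such a limit. For compound 3 the reading > 80 ug/mL is likewise a limit. Compound 2 also stands only at a limit, (the limit of < 10 ug/mL in this assay, at which 1 of the 3 values shown sits), so its true position on the scale is not resolved.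

Compound 4 `O=C(O)c1ccc(/C=C/C(=O)c2ccc(Cl)cc2)cc1` is not yet measured. It differs from compound 2 by chloro in place of isobutyl on an aromatic carbon. For the measured compounds named here, the only measured step, a step that the two limits leave unreadable from compound 1 to compound 3, concerns a different change and its size cannot be read from two limits, so no measured step bears on the change from compound 2 to compound 4. With nothing to point in either direction, no step beyond the scatter is expected, and compound 4 is estimated at 8 ug/mL, within 2 ug/mL to 40 ug/mL, an expected step that the limit leaves unreadable from compound 2 to compound 4 from its parent.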

Compound 4, half-maximal cytotoxic concentration: < 10 ug/mL
Compound 4: only a limit was reported; the forecaster's own chance of this, stated with the estimate: 50%; the middle value lies beyond the limit too.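

No step can be read from compound 2 to compound 4 in this assay, because both readings are limits rather than numbers: the limit of < 10 ug/mL in this assay, at which 2 of the 4 values shown sit. The compounds shown leave open whether chloro in place of isobutyl on the shared core shifts the half-maximal cytotoxic concentration, and in which direction.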